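The source may hold more compounds than are shown below. What is called first, only, known or untested is meant among the compounds shown, and "the series" means these compounds.

Of the compounds shown here, three on one shared core have been measured in a functional assay on MDCK cells (Canis lupus familiaris) for inhibition (on this read-out lower numbers stand for higher toxicity in this test and higher numbers for lower toxicity in this test), so far. There compound 1 (`CCCCOc1nc(CC2(c3ccccc3)CCCO2)cc(=O)n1C`) gives 90000 nM and compound 2 (`CCCOc1nc(CC2(C)CCCO2)cc(=O)n1C`) gives 860000 nM while compound 3 (`Cn1c(OC2CCCCC2)nc(CC2(C)CCCO2)cc1=O`) gives 816000 nM in the same test. Compound 3 thus stands within the scatter of compound 2, and compound 1 lies beyond the scatter from both of them, on the lower side.

The next structure is compound 4 (`CCCCOc1nc(CC2(C)CCCO2)cc(=O)n1C`), reached by butyl in place of cyclohexyl on an oxygen on an aromatic ring. Going by the values given here, the one measured step at that same place, with cyclohexyl in place of propyl, is a 1.1-fold lower number from compound 2 to compound 3 (0.02 log units; within the scatter) and it lies within the scatter. Among the compounds with values here, compound 1 also carries butyl on that oxygen, but it differs from compound 4 elsewhere in the structure, and no measured pair isolates butyl on its own.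

On this evidence no step beyond the scatter is expected in this assay, and the estimated step reads a 1.0-fold higher number from compound 3 to compound 4 (0.00 log units; within the scatter) here. For compound 4 the expected value is 820000 nM with an estimated range from 450000 nM to 1300000 nM in this test.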

Compound 4, half-maximal cytotoxic concentration: 1080000 nM
Compound 4: the middle estimate sits 1.3-fold (0.12 log units) below what was measured; the range from low to high includes it.
By their numbers in this assay, from the lowest: compound 1; then compounds 3, 2 and 4 (each within the scatter of the next).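

In this assay the oxygen on the aromatic ring now carries three different groups on the same methyl-bearing core, and all three read alike: butyl in place of cyclohexyl gives a 1.3-fold higher number from compound 3 to compound 4 (0.12 log units; within the scatter) and butyl in place of propyl gives a 1.3-fold higher number from compound 2 to compound 4 (0.10 log units; within the scatter). This place therefore tolerates an open chain of either length or a six-membered carbon ring with no step beyond the scatter, and the change from cyclohexyl to butyl, which removes the ring, leaves the number within the scatter too. Going by these compounds alone, compound 4 also supplies the first pair that isolates the other place, since with butyl held constant on the oxygen, methyl in place of phenyl on a saturated ring carbon gives a 12-fold higher number from compound 1 to compound 4 (1.08 log units; beyond the scatter), a large step that ties the low number of compound 1 to the phenyl and not to the butyl. Nothing measured here bears on why these numbers fall as they do.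

The compounds shown leave open whether an amine, a carboxylic acid or a chain longer than butyl on that oxygen would also stay within the scatter. They also leave open how ethyl or a pyridine ring would read on the saturated ring carbon, and whether the phenyl step holds with propyl or cyclohexyl on the oxygen.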